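Taking the methoxy off compound 2

A few compounds are considered here, and "the series" means these few. Any claim that something is new, unique, unknown or untested is made for them only; others in the source may bear on it.

- compound 1 `COc1cc(-c2nccn2Cc2ccccc2)cc(OC)c1OC` gives > 100000 nM (a limit)
- compound 2 `COc1ccc(-n2ccnc2-c2cc(OC)c(OC)c(OC)c2)cc1[N+](=O)[O-]` gives 100 nM

Among the measured compounds shown here, both readings come from a functional assay on MDA-MB-468 cells (Homo sapiens) for antiproliferative activity, read by MTT assay, with a stated time of 72 h (on this read-out higher numbers stand for weaker inhibition and lower numbers for stronger inhibition), and no measured step links them. For the measured compounds named here, compound 2 holds the only number so far, with 100 nM as its value and no other number to set beside it. For compound 1 the reading is a limit, the limit of > 100000 nM in this assay, at which 1 of the 2 values shown sits, here.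

Compound 3 `COc1cc(-c2nccn2-c2cccc([N+](=O)[O-])c2)cc(OC)c1OC` carries hydrogen in place of methoxy on an aromatic carbon, with the rest of compound 2 unchanged (hydrogen in place of methoxy on an aromatic carbon). Going by the values given here, no measured step shows this change, so the expectation is tentative: a loss beyond the scatter in this assay toward weaker inhibition, of moderate to large size. The expected move is a 30-fold higher number from compound 2 to compound 3 (1.48 log units; beyond the scatter) in size. Compound 3 is estimated at 3000 nM with an expected range from 300 nM to 30000 nM and a limit reading remains possible.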

Compound 3, half-maximal inhibitory concentration: 7200 nM
Compound 3: the middle estimate sits 2.4-fold (0.38 log units) below what was measured; measured number inside the range.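

Hydrogen in place of methoxy in this assay gives a 72-fold higher number from compound 2 to compound 3 (1.86 log units; beyond the scatter) and so provides the first measured step in the series. It shows that this one position, ortho to a nitro group and para to a large group, is not indifferent, since compound 3 keeps the rest of compound 2 and still loses much of its inhibition. Nothing shown here accounts for the size of this loss.

The compounds shown leave open how other groups at this position compare, such as hydroxyl, ethoxy or an amine, which would tell whether methoxy itself matters or hydrogen is simply a poor replacement. Whether the same change costs as much without the nitro group also remains unresolved.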